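Replacing neopentyl with butyl at the assay limit

A few compounds are considered here, and "the series" means these few. Any claim that something is new, unique, unknown or untested is made for them only; others in the source may bear on it.

In a functional assay on A549 cells (Homo sapiens) for cytotoxicity, read by MTT assay, with a stated time of 72 h (a higher number here means a weaker inhibitor, a lower number a stronger inhibitor), compound 3 (`CC(C)(C)COC1OC(=O)C(Cl)=C1N1CCCCC1`) gives > 400000 nM as its result, a limit of the assay and not a number. Compound 1 (`CC(C)OC1OC(=O)C(Cl)=C1N1CCCCC1`) gives > 400000 nM as its result, which is also a limit. Measured steps offer little here: there is only a step that the two limits leave unreadable from compound 1 to compound 3 and it provides no size to build on.

Compound 4 (`CCCCOC1OC(=O)C(Cl)=C1N1CCCCC1`) differs from compound 3 by propyl in place of tert-butyl on a saturated chain carbon bound to an oxygen on a saturated carbon and so carries butyl in place of neopentyl. Compound 2 (`CCCCOC1OC(=O)C(Cl)=C1Cl`) also carries butoxy and gives 22500 nM in this assay but differs from compound 4 elsewhere on the core, so it is only a weak hint of stronger inhibition.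

With the limit of > 400000 nM in this assay, at which 2 of the 3 values shown sit, as the main evidence, compound 4 is expected to stay near that limit, and any movement should be towards stronger inhibition. The expected change is an at least 1.3-fold lower number from compound 3 to compound 4 (0.12 log units; that floor lies within the scatter) on this evidence. For compound 4 the estimate is 300000 nM with 90000 nM to 400000 nM as the expected range.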

Compound 4, half-maximal inhibitory concentration: 93300 nM
Beside the measured number, compound 4's estimate is 3.2-fold (0.51 log units) above it; the range from low to high includes it.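

On the piperidin-1-yl core, the group on the oxygen does affect the result: in this assay, butyl gives a readable number where neopentyl and isopropyl do not, with an at least 4.2-fold lower number from compound 3 to compound 4 (0.63 log units; beyond the scatter) and an at least 4.2-fold lower number from compound 1 to compound 4 (0.63 log units; beyond the scatter). Each of these steps starts from a limit and so gives only its smallest size, and the limit still dominates this small set: the limit of > 400000 nM in this assay, at which 2 of the 4 values shown sit.

With butoxy held fixed, the second place on the core can now be read too, as piperidin-1-yl in place of chloro gives a 4.1-fold higher number from compound 2 to compound 4 (0.62 log units; beyond the scatter).

From the compounds shown here alone, it remains open whether a longer chain such as hexyl on the oxygen would lower the number further. Going by these compounds, it is also open whether morpholin-4-yl in place of piperidin-1-yl would bring the number closer to that of compound 2.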